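The source may hold more compounds than are shown below. What is called first, only, known or untested is meant among the compounds shown, and "the series" means these compounds.

Of the compounds shown here, three built on a shared core have numbers so far in a functional assay on MDA-MB-231 cells (Homo sapiens) for inhibition, read by MTT assay, with a stated time of 72 h (on this read-out higher numbers stand for weaker inhibition and lower numbers for stronger inhibition), and they do not sit close together. Compound 1 `COc1ccccc1-c1csc2cnc(Nc3ccc(NC(=O)C4CCNCC4)cc3)nc12` stands at 1050 nM and compound 3 `COc1ccccc1-c1csc2cnc(Nc3ccc(C(=O)NCC4CCNCC4)c(F)c3)nc12` at 1530 nM while compound 2 `COc1ccccc1-c1csc2cnc(Nc3ccc(C(=O)NC4CCNCC4)c(C)c3)nc12` stands at 240 nM and so has the lowest number of the three. Its gap to each of the other two lies beyond the scatter of repeated measurements.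

Compound 4 `COc1ccccc1-c1csc2cnc(Nc3ccc(C(=O)NC4CCNCC4)cc3)nc12` is still unmeasured and differs from compound 2 by hydrogen in place of methyl on an aromatic carbon in a single place: hydrogen in place of methyl on an aromatic carbon. Going by the values given here, no two measured compounds differ in one place only, so the data give no direct measure of such a step. A modest step toward weaker inhibition is expected in this assay and it may stay close to the scatter. The only ground for this is that compound 2 at 240 nM already holds the lowest number, with compound 1 at 1050 nM and compound 3 at 1530 nM both higher. The estimated change is a 1.7-fold higher number from compound 2 to compound 4 (0.22 log units; within the scatter) on this reasoning. For compound 4 the estimated value is 400 nM with an expected range from 150 nM to 1000 nM in this measurement.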

Compound 4, half-maximal inhibitory concentration: 110 nM
The estimate for compound 4 lay 3.6-fold (0.56 log units) above the measured number; the whole stated range lies above it.
By their numbers in this assay, from the lowest: compound 4; then compound 2; then compounds 1 and 3 (each within the scatter of the next).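

In this assay, going by these compounds alone, hydrogen in place of methyl on the aromatic carbon ortho to the (piperidin-4-yl)carbamoyl group gives a 2.2-fold lower number from compound 2 to compound 4 (0.34 log units; beyond the scatter), the first one-place reading at this position, and it shows that the methyl is not needed for a low number here and that the ring without it gives the stronger inhibition of the pair. Within the data shown here, the same compound also gives the first reading of how the amide link is set on the aromatic ring: (piperidin-4-yl)carbamoyl in place of ((piperidin-4-yl)carbonyl)amino gives a 9.5-fold lower number from compound 1 to compound 4 (0.98 log units; beyond the scatter), so the two arrangements of this link are not interchangeable in this pair. No supporting data are available to account for either step.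

The compounds shown leave open whether any other group on that aromatic carbon, such as chlorine or a hydroxyl group, would match hydrogen, since methyl is the only substituent there that can be compared directly. They also leave open what an open-chain amine in place of the piperidine would do, and compound 3 differs from compound 4 in more than one place, so it gives no one-place comparison with it.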